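The source may report more compounds than this note shows. Statements on the series, on what has been measured and on what is new or still open speak of the compounds shown alone.

Compound 1 `Nc1cnc2c(OCc3ccccc3)cccn12`, compound 2 `CC(=O)Nc1c(C)nc2c(OCc3ccccc3)cccn12` and compound 3 `Cc1nc2c(OCc3ccccc3)cccn2c1NC(=O)OCc1ccccc1` share one core and have been measured in a functional assay on the whole organism with Canis familiaris (Canis lupus familiaris) as the target, at a dose of 2 mg/kg by the intravenous route; on this read-out lower numbers stand for a weaker effect and higher numbers for a stronger effect at the one dose given. In this assay compound 1 gives 81%, compound 2 gives 24% and compound 3 gives 82%. Compound 2 stands lowest of the three numbers; its nearest neighbour is compound 1, its furthest compound 3, both beyond the scatter. Among the measured compounds shown here, the one measured single-place step is a number 58 percentage points higher from compound 2 to compound 3 (beyond the scatter), with benzyloxy in place of methyl on a carbonyl carbon. Compound 4 `CCCNc1c(C)nc2c(OCc3ccccc3)cccn12` is not yet measured in this assay. It differs from compound 2 as follows: propyl in place of acetyl on a nitrogen on an aromatic ring. For the measured compounds named here, no measured step carries the same change, so the step from compound 2 to compound 3 bears on it only loosely, as a large upward move away from the acetamido of compound 2; the values of compound 1 and compound 2 show that the compound without acetyl on that nitrogen sits far higher. A step upward beyond the scatter is therefore expected in this assay, of size a number 36 percentage points higher from compound 2 to compound 4 (beyond the scatter). For compound 4 the estimate in this assay is 60%, within a range from 30% to 85%.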

Compound 4, a percentage reported as inhibition, in the whole organism at one dose (the size of the read-out at that dose, not a potency): 12%
Beside the measured number, compound 4's estimate is 48 percentage points above it; the whole stated range lies above it.
By their numbers in this assay, from the lowest: compound 4; then compound 2; then compounds 1 and 3 (each within the scatter of the next).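

In this assay, propyl in place of acetyl on the nitrogen gives a number 12 percentage points lower from compound 2 to compound 4 (beyond the scatter), so swapping acetyl for a chain of the same heavy-atom count removes the carbonyl without raising the read-out. The acetamido group of compound 2 therefore does not mark the bottom of what this nitrogen can carry, and the substituent there can move the number down as well as up. Among the three methyl-bearing compounds, a plain alkyl chain does not match the carbamate: compound 4 gives 12% and compound 3 gives 82%, which leaves propylamino and acetamido both at the low end of this small set.

The compounds shown leave open whether the unsubstituted amine on the methyl-bearing core would read high, which would separate the part played by the ring methyl from that of the nitrogen substituent. They also leave open whether a benzyl group or a longer chain on this nitrogen would behave like propyl or like the benzyloxy-bearing carbonyl of compound 3. No measurement at hand speaks to what lies behind the lower number of compound 4.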